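The source may report more compounds than this note shows. Statements on the series, on what has been measured and on what is new or still open speak of the compounds shown alone.

Working notes on the series. In an ADME assay on L929 cells (Mus musculus, culture collection number NCTC 929) for cytotoxicity, read by MTT assay, with a stated time of 72 h (on this read-out lower numbers stand for stronger inhibition and higher numbers for weaker inhibition), compound 1 `Cc1cc(O)c(CCC2CCCCC2)c(=O)o1` gives 109000 nM and compound 2 `CCCCCCCCCC(=O)c1c(O)cc(C)oc1=O` gives 134000 nM. These two values lie within the scatter of each other, so compound 2 stands level with compound 1 and both sit in the same high range of numbers, which means weak inhibition.

Compound 3 `CCCCCCCCCCCCCC(=O)c1c(O)cc(C)oc1=O` differs from compound 2 by butyl in place of hydrogen on a saturated chain carbon, nine bonds along the chain from a carbonyl carbon. In words, this is butyl in place of hydrogen on a saturated chain carbon, nine bonds along the chain from a carbonyl carbon. The same difference also reads as methyl to pentyl.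

Among the measured compounds shown here, no pair of measured compounds differs in one place only, so the data hold no direct measure of this change. The expectation therefore rests on compound 2 at 134000 nM as the anchor, and it remains tentative. A modest shift in this assay towards lower numbers is expected, though a result within the scatter would not surprise.

The expected step is a 1.9-fold lower number from compound 2 to compound 3 (0.28 log units; within the scatter).

For compound 3 the estimated value is 70000 nM, with an expected range of 25000 nM to 170000 nM.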

Compound 3, half-maximal inhibitory concentration: > 200000 nM
Compound 3: a limit, no number; the forecaster's own chance of this, stated with the estimate: 15%; middle value at least 2.8-fold (0.45 log units) away from the limit.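

Compound 3 gives > 200000 nM in this assay, which is a limit of the assay and not a number. Butyl in place of hydrogen on a saturated chain carbon, nine bonds along the chain from a carbonyl carbon, gives an at least 1.4-fold higher number from compound 2 to compound 3 (0.17 log units; that floor lies within the scatter), so this first look at the position shows no move towards lower numbers on lengthening the chain from compound 2 to compound 3, and the series stays in the range of weak inhibition. The size of this change has only a floor and no measured value, because the reading for compound 3 rests on this: the limit of > 200000 nM in this assay, at which 1 of the 3 values shown sits.

The compounds shown leave open whether an amine or a carboxylic acid in place of hydrogen at this same position would bring the number into a lower range, and whether a chain of intermediate length would read as a number and not as a limit. From the compounds shown here alone, compound 1 differs from compound 3 in more than one place, so it offers no read on this change, and how the position behaves with any other group remains unknown.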